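Swapping a pyridin-3-yl for a chloro on the phenol ring

The source may report more compounds than this note shows. Statements on the series, on what has been measured and on what is new or still open speak of the compounds shown alone.

These compounds were tested in a functional assay on HL-60 cells (Homo sapiens) for cytotoxicity, read by luminescence and CellTiter-Glo, with a stated time of 3 days; a lower number here means a stronger inhibitor, a higher number a weaker inhibitor. Compound 1, with the structure `N#Cc1ccc(NC(=O)c2cc(-c3cccnc3)ccc2O)cc1`, gives 7960 nM in this assay. Compound 2, with the structure `N#Cc1ccc(NC(=O)c2ccc3cccnc3c2O)cc1`, gives 370 nM in this assay, so compound 1 holds the higher of the two numbers, and the gap between them lies beyond the usual scatter. Compound 3, with the structure `Cc1cccc(C(=O)Nc2ccc(C#N)cc2)c1O`, reaches only the limit of this assay, > 10000 nM, which is not a number but the edge of what was measured; this is the limit described as the limit of > 10000 nM in this assay, at which 1 of the 3 values shown sits.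

Compound 4, with the structure `N#Cc1ccc(NC(=O)c2cc(Cl)ccc2O)cc1`, is not yet measured. It differs from compound 1 in one place: chloro in place of pyridin-3-yl on an aromatic carbon. Among the compounds with values here, no measured pair shows this kind of change, so the direction of the step has to be guessed. The step from compound 1 to compound 4 in this assay is expected to be about a 1.1-fold higher number from compound 1 to compound 4 (0.05 log units; within the scatter), with no clear pull beyond the scatter either way. Compound 4 is estimated to give 9000 nM, within a range from 2500 nM to 30000 nM.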

Compound 4, half-maximal inhibitory concentration: 700 nM
The estimate for compound 4 lay 13-fold (1.11 log units) above the measured number; measured number below the stated range.
By their numbers in this assay, from the lowest: compounds 2 and 4 (each within the scatter of the next); then compound 1. At a limit, above all of these: compound 3.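

In this assay, chloro in place of pyridin-3-yl on the aromatic carbon para to a hydroxy group gives an 11-fold lower number from compound 1 to compound 4 (1.06 log units; beyond the scatter), so the number clearly depends on what sits at this position. Within the data shown here, a ring at this carbon is therefore not needed for the lower number, since the single chlorine atom of compound 4 gives the stronger result of this pair. Nothing shown here explains why this swap lowers the number.

Going by these compounds, with only these two groups compared at this position, it remains open whether the drop comes from the presence of chloro or from the loss of pyridin-3-yl. A fluoro, a methoxy or an amine on the same carbon would help to separate these two readings, and a phenyl would show whether the ring nitrogen matters.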